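This account rests on a few compounds, and the source may have more. Where it says the series, first, only, none or still open, it means among the compounds named here.

In a functional assay on PC-3 cells (Homo sapiens) for antiproliferative activity, read by MTT assay (a lower number here means a stronger inhibitor, a higher number a weaker inhibitor), compound 3 `COc1ccc(/C=N/Nc2ncc3c(n2)n(C2CCCC2)c(=O)c(=O)n3C)c(OC)c1` gives > 100000 nM, which is a limit of the assay rather than a measured number. Compound 1 `Cn1c(=O)c(=O)n(C2CCCC2)c2nc(N/N=C/c3cccs3)ncc21` in this assay gives 75600 nM. Compound 2 `Cc1ccc(/C=N/Nc2ncc3c(n2)n(C2CCCC2)c(=O)c(=O)n3C)cc1C` in this assay gives 39000 nM. Compound 3 therefore stands at the weak end of the three, marked by the limit of > 100000 nM in this assay, at which 1 of the 3 values shown sits. The step to compound 4 `Cn1c(=O)c(=O)n(C2CCCC2)c2nc(N/N=C/c3ccc(F)cc3Br)ncc21` again changes the aromatic group on the carbon that carries the double bond to nitrogen: 2-bromo-4-fluorophenyl in place of 2,4-dimethoxyphenyl on a carbon with a double bond to nitrogen. Among the compounds with values here, three measured steps bear on it, all swaps of this same group. The step of a 1.9-fold lower number from compound 1 to compound 2 (0.29 log units; within the scatter) was small, and the step of an at least 1.3-fold higher number from compound 1 to compound 3 (0.12 log units; that floor lies within the scatter) also stays inside the scatter, while the step of an at least 2.5-fold higher number from compound 2 to compound 3 (0.40 log units; beyond the scatter) lies beyond it. Because the step of an at least 2.5-fold higher number from compound 2 to compound 3 (0.40 log units; beyond the scatter) went toward weaker inhibition, moving away from the dimethoxyphenyl is expected to undo part of that, so for compound 4 a step of an at least 1.6-fold lower number from compound 3 to compound 4 (0.22 log units; that floor lies within the scatter) is expected in this assay. Compound 4 is estimated in this assay at 60000 nM, with a likely range from 25000 nM to 150000 nM.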

Compound 4, half-maximal inhibitory concentration: 9250 nM
Beside the measured number, compound 4's estimate is 6.5-fold (0.81 log units) above it; the whole stated range lies above it.
By their numbers in this assay, from the lowest: compound 4; then compounds 2 and 1 (each within the scatter of the next). At a limit, above all of these: compound 3.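

Swapping the aromatic group on the carbon with a double bond to nitrogen can change the result in this assay more than the earlier compounds showed, and compound 4 is the strongest inhibitor of the four: 2-bromo-4-fluorophenyl gives a 4.2-fold lower number from compound 2 to compound 4 (0.62 log units; beyond the scatter) and an 8.2-fold lower number from compound 1 to compound 4 (0.91 log units; beyond the scatter). The largest step is an at least 10-fold lower number from compound 3 to compound 4 (1.03 log units; beyond the scatter). That size is only a floor, as compound 3 is held at a limit of the assay rather than a measured number: the limit of > 100000 nM in this assay, at which 1 of the 4 values shown sits.

The compounds shown do not separate the bromine from the fluorine in 2-bromo-4-fluorophenyl, so neither atom can be credited with the gain on its own. From the compounds shown here alone, how a phenyl ring carrying an amine or a carboxylic acid would behave at this place also remains open.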